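Ring nitrogen in place of ring carbon at the carbonyl

The source may report more compounds than this note shows. Statements on the series, on what has been measured and on what is new or still open speak of the compounds shown alone.

Measured in an assay on HEK293 cells for positive allosteric modulation of metabotropic glutamate receptor 5 (Homo sapiens), read by FLIPR; on this read-out higher numbers stand for an effect only at larger amounts of compound and lower numbers for an effect already at smaller amounts:
compound 1 `CC1CCC(C(=O)N2CC(c3nc(-c4cccc(Cl)c4)no3)C2)CC1` gives 1500 nM
compound 2 `O=C(C1CCC(C(F)(F)F)CC1)N1CC(c2nc(-c3cccc(Cl)c3)no2)C1` gives 1000 nM
compound 3 `O=S(=O)(c1ccc(Cl)cc1)N1CC(c2nc(-c3cccc(Cl)c3)no2)C1` gives > 10000 nM, which is a limit of this assay and not a number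

Compound 1 holds the higher of the two numbers; the nearest is a 1.5-fold lower number from compound 1 to compound 2 (0.18 log units; within the scatter). Within the data shown here, the only other value, that of compound 3, sits at the limit of > 10000 nM in this assay, at which 1 of the 3 values shown sits. Compound 4 `CC1CCN(C(=O)N2CC(c3nc(-c4cccc(Cl)c4)no3)C2)CC1` differs from compound 1 by 4-methylpiperidin-1-yl in place of 4-methylcyclohexyl on a carbonyl carbon. Among the measured compounds shown here, no measured step touches the carbonyl carbon: the single measured step alters a saturated ring carbon and stays within the scatter, and compound 3 has no single-change step to compound 1. The expectation for compound 4 is therefore a step of a 1.3-fold higher number from compound 1 to compound 4 (0.12 log units; within the scatter), not beyond the scatter. Compound 4 is estimated at 2000 nM, between 700 nM and 6000 nM.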

Compound 4, half-maximal effective concentration: 865 nM
Estimate against measurement, compound 4: 2.3-fold (0.36 log units) above, and the stated range covers the measured number.
By their numbers in this assay, from the lowest: compounds 4, 2 and 1 (each within the scatter of the next). At a limit, above all of these: compound 3.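

In this assay, 4-methylpiperidin-1-yl in place of 4-methylcyclohexyl on the carbonyl carbon gives a 1.7-fold lower number from compound 1 to compound 4 (0.24 log units; within the scatter). Among these compounds, this is the first measured change at the carbonyl carbon itself, and a ring nitrogen bound there in place of ring carbon keeps the read-out within the scatter. Nothing at hand bears on why this step is so small.

Open, as far as these compounds go, is whether the position accepts a morpholine, an open-chain dialkylamine or a free amine on the carbonyl carbon. Also open, from the compounds shown here alone, is whether 4-(trifluoromethyl)piperidin-1-yl would read like compound 4.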